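A Trifluoromethoxy Shift Among Closely Matched Compounds

The source may report more compounds than this note shows. Statements on the series, on what has been measured and on what is new or still open speak of the compounds shown alone.

In a functional assay on VCaP cells (Homo sapiens) for antiproliferative activity, read by fluorescence and propidium iodide staining, with a stated time of 96 h (on this read-out lower numbers stand for stronger inhibition and higher numbers for weaker inhibition), compound 1 (`CC(O)(CS(=O)(=O)c1cccc(C(F)(F)F)c1)C(=O)Nc1cc(C(F)(F)F)cc(C(F)(F)F)c1`) gives 9980 nM and compound 2 (`CC(O)(CS(=O)(=O)c1ccccc1C(F)(F)F)C(=O)Nc1cc(C(F)(F)F)cc(C(F)(F)F)c1`) gives 8550 nM while compound 3 (`CC(O)(CS(=O)(=O)c1cccc(OC(F)(F)F)c1)C(=O)Nc1cc(C(F)(F)F)cc(C(F)(F)F)c1`) gives 9990 nM and so sits level with both within the scatter. Compound 4 (`CC(O)(CS(=O)(=O)c1ccccc1OC(F)(F)F)C(=O)Nc1cc(C(F)(F)F)cc(C(F)(F)F)c1`) carries 2-(trifluoromethoxy)phenyl in place of 3-(trifluoromethoxy)phenyl on a sulfonyl sulfur. The matching change with trifluoromethyl gave a 1.2-fold lower number from compound 1 to compound 2 (0.07 log units; within the scatter) and trifluoromethoxy in place of trifluoromethyl gave a 1.0-fold higher number from compound 1 to compound 3 (0.00 log units; within the scatter) in the same measurements. Neither step leaves the scatter, so the expected step of a 1.1-fold lower number from compound 3 to compound 4 (0.05 log units; within the scatter) should be no larger than the scatter in this assay and has no clear direction. Compound 4 is estimated at 9000 nM (expected range 5500 nM to 13000 nM).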

Compound 4, half-maximal inhibitory concentration: 9950 nM
Beside the measured number, compound 4's estimate is 1.1-fold (0.04 log units) below it; low and high end bracket the measured number.
By their numbers in this assay, from the lowest: compounds 2, 4, 1 and 3 (each within the scatter of the next).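

Setting 2-(trifluoromethoxy)phenyl in place of 3-(trifluoromethoxy)phenyl on the sulfonyl sulfur gives, in this assay, a 1.0-fold lower number from compound 3 to compound 4 (0.00 log units; within the scatter), and the step of a 1.0-fold lower number from compound 1 to compound 4 (0.00 log units; within the scatter) is just as small. Trifluoromethoxy in place of trifluoromethyl can now be read on a second pair, a 1.2-fold higher number from compound 2 to compound 4 (0.07 log units; within the scatter), and the two readings agree: the same change on two cores in this assay, a 1.0-fold higher number (0.00 log units; within the scatter) from compound 1 to compound 3 and a 1.2-fold higher number (0.07 log units; within the scatter) from compound 2 to compound 4, 1.2-fold (0.07 log units) apart, within the scatter of two such steps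

Across these four compounds, neither group nor either of these placements moves the number beyond the scatter. From the compounds shown here alone, whether an amine or a carboxylic acid at this position would do so remains open, and so does the effect of changes elsewhere on the shared core.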